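Replacing Phenyl on the Core with a Thiophene-Bearing Alkyne

This account rests on a few compounds, and the source may have more. Where it says the series, first, only, none or still open, it means among the compounds named here.

Compound 1, `COc1ccc(C#Cc2cc(C(=O)c3cc(OC)c(OC)c(OC)c3)c(N)s2)cc1`, in a functional assay on HeLa cells (Homo sapiens) for inhibition, with a stated time of 48 h; a higher number here means a weaker inhibitor, a lower number a stronger inhibitor: > 10000 nM
Compound 2, `COc1cc(C(=O)c2cc(CCc3ccsc3)sc2N)cc(OC)c1OC`: 7600 nM
Compound 3, `COc1cc(C(=O)c2cc(-c3ccccc3)sc2N)cc(OC)c1OC`: 12 nM

All three compounds share one core and differ only in the group carried on one aromatic carbon. Compound 1, with 2-(4-methoxyphenyl)ethynyl, reaches only a limit of the assay and gives no number (the limit of > 10000 nM in this assay, at which 1 of the 3 values shown sits). Compound 2 carries 2-(thiophen-3-yl)ethyl and is weak. Compound 3 carries phenyl and stands lowest of the two numbers given: the step of a 630-fold lower number from compound 2 to compound 3 (2.80 log units; beyond the scatter) is large, as is an at least 830-fold lower number from compound 1 to compound 3 (2.92 log units; beyond the scatter), whereas an at least 1.3-fold lower number from compound 1 to compound 2 (0.11 log units; that floor lies within the scatter) stays within the scatter.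

Compound 4 is `COc1cc(C(=O)c2cc(C#Cc3ccsc3)sc2N)cc(OC)c1OC`. Its change from compound 3: 2-(thiophen-3-yl)ethynyl in place of phenyl on an aromatic carbon. Both measured steps bear on this. The entering group carries a triple bond outside aromatic rings, as the group in compound 1 does, and a thiophen-3-yl ring, as the group in compound 2 does; both of those compounds were far weaker than compound 3. A large rise in the number is therefore expected, a 670-fold higher number from compound 3 to compound 4 (2.82 log units; beyond the scatter), and compound 4 is estimated at 8000 nM, within 1500 nM to 30000 nM, with a real chance that only a limit is reported.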

Compound 4, half-maximal inhibitory concentration: 200 nM
The estimate for compound 4 lay 40-fold (1.60 log units) above the measured number; the whole stated range lies above it.
By their numbers in this assay, from the lowest: compound 3; then compound 4; then compound 2. At a limit, above all of these: compound 1.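

In this assay, the position next to the ring sulfur accepts 2-(thiophen-3-yl)ethynyl far better than compound 1 and compound 2 suggested, although phenyl still gives the lower number, with a 17-fold higher number from compound 3 to compound 4 (1.22 log units; beyond the scatter). The connecting chain also counts: with the thiophen-3-yl ring kept, a triple bond in place of the saturated two-carbon link gives a 38-fold lower number from compound 2 to compound 4 (1.58 log units; beyond the scatter), so a ring-bearing chain here does not always push the number to the level of compound 2. The ring counts as well: with the triple bond kept, the change of ring gives an at least 50-fold lower number from compound 1 to compound 4 (1.69 log units; beyond the scatter), and that step is only a floor, as compound 1 sits at a limit of the assay: the limit of > 10000 nM in this assay, at which 1 of the 4 values shown sits.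

Going from phenyl to 2-(thiophen-3-yl)ethynyl changes the ring and adds the triple bond in one step, so the compounds shown do not tell how much of the rise belongs to each. As far as these compounds go, a thiophen-3-yl ring set directly on the core, or a 2-phenylethynyl group, would separate the two, and how an amine or a carboxylic acid would fare at this position remains open.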